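A few compounds are considered here, and "the series" means these few. Any claim that something is new, unique, unknown or untested is made for them only; others in the source may bear on it.

Compound 1, `CC1=C(C(=O)Nc2ccc(F)c(Cl)c2)C(c2cccc(Cl)c2)NC(=S)N1`: 14100 nM
Compound 2, `CC1=C(C(=O)Nc2ccc(F)c(Cl)c2)C(c2cccc(Oc3ccccc3)c2)NC(=S)N1`: 10700 nM

Of the compounds shown here, two have so far been measured in a functional assay on IGROV-1 cells (Homo sapiens) for cytotoxicity, read by sulforhodamine B assay, with a stated time of 48 h (a higher number here means a weaker inhibitor of growth, a lower number a stronger inhibitor of growth), and they sit within the usual scatter of each other. In this assay, for the measured compounds named here, compound 1 gives 14100 nM, while compound 2 gives 10700 nM; the only recorded step, a 1.3-fold lower number from compound 1 to compound 2 (0.12 log units; within the scatter), corresponds to swapping a chloro for a phenoxy on the aromatic ring attached to the shared core and does not separate the two beyond the scatter.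

Compound 3, `COc1cccc(C2NC(=S)NC(C)=C2C(=O)Nc2ccc(F)c(Cl)c2)c1`, has not yet been measured. It differs from compound 2 by methyl in place of phenyl on an oxygen on an aromatic ring, so the phenoxy of compound 2 becomes a methoxy. Going by the values given here, no measured step bears directly on this change: the single step available concerns what the aromatic ring carries, not what sits on that oxygen, and it was itself within the scatter. With nothing pointing either way, the step of a 1.1-fold higher number from compound 2 to compound 3 (0.05 log units; within the scatter) is expected to stay within the scatter. Compound 3 is therefore estimated at 12000 nM, within a range from 5000 nM to 30000 nM.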

Compound 3, concentration for 50% growth inhibition: 27500 nM
Estimate against measurement, compound 3: 2.3-fold (0.36 log units) below; the measured number falls inside the stated range.
By their numbers in this assay, from the lowest: compounds 2, 1 and 3 (each within the scatter of the next, the first and the last beyond it).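

In this assay, for the compounds shown here, the change on the oxygen gives the first step that clears the scatter: a 2.6-fold higher number from compound 2 to compound 3 (0.41 log units; beyond the scatter). The step is modest, but it shows that what sits on this oxygen can shift the number, which the earlier swap of chloro for phenoxy could not show. The other new step, methoxy in place of chloro on the aromatic carbon, is a 2.0-fold higher number from compound 1 to compound 3 (0.29 log units; within the scatter), so compound 1 is not set apart from either of the other two, and the only separation lies between the phenoxy and methoxy compounds. Nothing measured here explains why swapping phenyl for methyl on the oxygen gives this difference.

On these data alone, it remains open whether a group of intermediate size on the oxygen, such as an ethyl or a benzyl group, would give a number closer to that of compound 2 or that of compound 3. As far as these compounds go, it is also open whether a hydroxy group or an amine in place of the whole methoxy would move the number beyond the scatter in either direction.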